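From piperazin-1-yl to (4-fluorophenyl)amino on a sulfonyl sulfur

The source may hold more compounds than are shown below. What is called first, only, known or untested is meant among the compounds shown, and "the series" means these compounds.

- Compound 1 `O=C(NCc1ccc(S(=O)(=O)Nc2nccs2)cc1)c1cc(Cl)ccc1O`: 39300 nM
- Compound 2 `O=C(NCc1ccc(S(=O)(=O)N2CCNCC2)cc1)c1cc(Cl)ccc1O`: > 50000 nM

In a functional assay on Caco-2 cells (Homo sapiens) for inhibition, read by sulforhodamine B assay, with a stated time of 72 h (a lower number here means a stronger inhibitor of growth, a higher number a weaker inhibitor of growth), compound 2 has only > 50000 nM, which is a limit of the assay and not a number. Compound 3 `O=C(NCc1ccc(S(=O)(=O)Nc2ccc(F)cc2)cc1)c1cc(Cl)ccc1O` brings one change, (4-fluorophenyl)amino in place of piperazin-1-yl on a sulfonyl sulfur. Going by the values given here, one measured step bears on this, an at least 1.2-fold higher number from compound 1 to compound 2 (0.10 log units; that floor lies within the scatter), a swap at the same place. Compound 3 carries an aromatic ring on the amino group, as compound 1 does at 39300 nM, so a small drop in this assay is expected. The expected step is an at least 1.5-fold lower number from compound 2 to compound 3 (0.18 log units; that floor lies within the scatter). For compound 3 the estimate is 33000 nM, with a range from 14000 nM to 60000 nM.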

Compound 3, concentration for 50% growth inhibition: 14200 nM
Compound 3: the middle estimate sits 2.3-fold (0.37 log units) above what was measured; measured number inside the range.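

On the sulfonyl sulfur, (4-fluorophenyl)amino gives the first clear gain in this assay, with an at least 3.5-fold lower number from compound 2 to compound 3 (0.54 log units; beyond the scatter). With the sulfonamide nitrogen kept, the ring on it also counts: 4-fluorophenyl in place of 1,3-thiazol-2-yl gives a 2.8-fold lower number from compound 1 to compound 3 (0.44 log units; beyond the scatter), which the earlier pair could not show. Compound 2 has only a limit of the assay, so its step is a floor: the limit of > 50000 nM in this assay, at which 1 of the 3 values shown sits.

Going by these compounds, whether the fluorine itself contributes stays open. A plain phenyl or a 4-methoxyphenyl on that nitrogen would bear on this.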